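The source may hold more compounds than are shown below. What is called first, only, known or untested is meant among the compounds shown, and "the series" means these compounds.

In a functional assay on Jurkat cells for inhibition of nuclear factor NF-kappa-B complex (Homo sapiens) (a lower number here means a stronger inhibitor, a higher number a weaker inhibitor), three compounds sharing one core have been measured:

compound 1 `CCOC(=O)c1cnc(-c2cc(Cl)nc(Cl)c2)nc1NN1C(=O)C=C(C)C1=O`: 2000 nM
compound 2 `CCOC(=O)c1cnc(-c2cnc3ccccc3c2)nc1NN1C(=O)C=C(C)C1=O`: 6000 nM
compound 3 `CCOC(=O)c1cnc(-c2ccc(OC)cc2)nc1NN1C(=O)C=C(C)C1=O`: 900 nM

Compound 3 has the lowest number of the three. The step of a 2.2-fold lower number from compound 1 to compound 3 (0.35 log units; beyond the scatter) and the step of a 6.7-fold lower number from compound 2 to compound 3 (0.82 log units; beyond the scatter) both lie beyond the scatter, so compound 3 is the strongest inhibitor of the set, with compound 1 nearest to it and compound 2 furthest.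

Compound 4 `CCOC(=O)c1cnc(C2CC2)nc1NN1C(=O)C=C(C)C1=O` is the next compound. Its change from compound 3 is cyclopropyl in place of 4-methoxyphenyl on an aromatic carbon. Among the measured compounds shown here, no measured step exchanges an aromatic group for a non-aromatic one. For the measured compounds named here, the steps that bear on it, a 3.0-fold higher number from compound 1 to compound 2 (0.48 log units; beyond the scatter) and a 2.2-fold lower number from compound 1 to compound 3 (0.35 log units; beyond the scatter), only exchange one six-membered aromatic ring for another, and they moved the number by modest amounts in either direction. The change to compound 4 goes further than any of them, so a higher number, that is a weaker inhibitor, is expected, of a size beyond the scatter but still modest. Compound 4 is therefore expected to give 3000 nM, between 800 nM and 12000 nM. That expectation means the step of a 3.3-fold higher number from compound 3 to compound 4 (0.52 log units; beyond the scatter).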

Compound 4, half-maximal inhibitory concentration: 1000 nM
Compound 4: middle estimate off by 3.0-fold (0.48 log units), on the high side; low and high end bracket the measured number.
By their numbers in this assay, from the lowest: compounds 3, 4 and 1 (each within the scatter of the next, the first and the last beyond it); then compound 2.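

In this assay, the position between two ring nitrogen atoms does not need an aromatic ring: exchanging 4-methoxyphenyl for cyclopropyl, with its 3 heavy atoms against 8, gives a 1.1-fold higher number from compound 3 to compound 4 (0.05 log units; within the scatter). Among the compounds shown here, the exchange from 2,6-dichloropyridin-4-yl also stays within the scatter, at a 2.0-fold lower number from compound 1 to compound 4 (0.30 log units; within the scatter), whereas the exchange from quinolin-3-yl gives a 6.0-fold lower number from compound 2 to compound 4 (0.78 log units; beyond the scatter), which leaves compound 2 as the only compound set apart from all three others. No measurement shown here accounts for this result.

The compounds shown leave open whether an open-chain group such as a longer alkyl chain, or an amine, at this position would give a number like that of compound 4. They also leave open whether a larger saturated ring such as cyclohexyl would do the same, and whether the cyclopropyl result would hold with a carboxylic acid in place of the ethoxycarbonyl group.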